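The source may report more compounds than this note shows. Statements on the series, on what has been measured and on what is new or still open speak of the compounds shown alone.

Working notes on the series. Compound 3 `CC1CCN(c2cc(C(C)(C)C)ccc2CNC(=O)C(C)c2ccc(NS(C)(=O)=O)c(F)c2)CC1` is the most potent of the three measured compounds in an assay on cells for antagonist activity at transient receptor potential cation channel subfamily V member 1 (Homo sapiens), read by FLIPR and calcium flux, with a stated time of 6 min; a higher number here means a weaker inhibitor, a lower number a stronger inhibitor: compound 3 gives 0.7 nM. Compound 1 `CC(C)Oc1nc(C(C)(C)C)ccc1CNC(=O)C(C)c1ccc(NS(C)(=O)=O)c(F)c1` gives 2.3 nM and compound 2 `CC(C(=O)NCc1ccc(C(C)(C)C)nc1C1CCCCC1)c1ccc(NS(C)(=O)=O)c(F)c1` gives 3.1 nM; both of these higher numbers lie beyond the scatter from compound 3.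

Compound 4 `CC(C(=O)NCc1ccc(C(C)(C)C)cc1C1CCCCC1)c1ccc(NS(C)(=O)=O)c(F)c1` differs from compound 3 by cyclohexyl in place of 4-methylpiperidin-1-yl on an aromatic carbon. Within the data shown here, the only measured step that bears on this exchange is a 1.3-fold higher number from compound 1 to compound 2 (0.13 log units; within the scatter), where cyclohexyl also enters, but isopropoxy leaves, and on the core of compound 1 rather than on the six-membered aromatic ring of carbon only. Among the measured compounds shown here, no measured pair shows 4-methylpiperidin-1-yl leaving. The gap between compound 3 and the other two compounds combines a change of the aromatic ring with a change of this group, so the contribution of the group alone cannot be read from it.

The expectation is that cyclohexyl in compound 4 performs much as it does in compound 2, so the number for compound 4 is expected to move somewhat toward those of compound 1 and compound 2, an estimated step of a 2.6-fold higher number from compound 3 to compound 4 (0.41 log units; beyond the scatter), because the cyclohexyl step a 1.3-fold higher number from compound 1 to compound 2 (0.13 log units; within the scatter) was itself small. Compound 4 in this assay is estimated at 1.8 nM, with a range of 0.6 nM to 5 nM.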

Compound 4, inhibition constant: 9.8 nM
Compound 4: middle estimate off by 5.4-fold (0.74 log units), on the low side; the whole stated range lies below it.
By their numbers in this assay, from the lowest: compound 3; then compounds 1 and 2 (each within the scatter of the next); then compound 4.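

At the aromatic carbon ortho to a large group and meta to the tert-butyl group, cyclohexyl in place of 4-methylpiperidin-1-yl is far from a neutral exchange in this assay: the result is a 14-fold higher number from compound 3 to compound 4 (1.15 log units; beyond the scatter), even though one six-membered non-aromatic ring replaces another. The step is much larger than a 1.3-fold higher number from compound 1 to compound 2 (0.13 log units; within the scatter), which was read on a different core with isopropoxy leaving, so the small cyclohexyl step there does not carry over to this exchange, and the identity of the group that leaves matters at this position. The exchange removes one ring nitrogen, which is the hydrogen-bond acceptor counted for the group that leaves, and also changes the heavy-atom count, but nothing available gives a measured account of the step.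

The compounds shown leave open whether the difference follows the ring nitrogen or the methyl group, a question that an unsubstituted piperidin-1-yl, a morpholin-4-yl or a 4-methylcyclohexyl at this carbon would help to separate. They also leave open whether 4-methylpiperidin-1-yl would give a comparable number on the core of compound 1.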